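The source may hold more compounds than are shown below. What is called first, only, known or untested is meant among the compounds shown, and "the series" means these compounds.

Compound 1 `O=C1O/C(=C\Cn2cc(-c3cc(F)cc(F)c3)nn2)C(OCc2ccccc2)=C1OCc1ccccc1` carries a 3,5-difluorophenyl group on its shared core. In a functional assay on A549 cells (Homo sapiens) for antiproliferative activity, read by MTT assay, with a stated time of 72 h (a higher number here means a weaker inhibitor, a lower number a stronger inhibitor), compound 1 gives only a limit, > 100000 nM, so no exact number is known for it. That limit is the point (the limit of > 100000 nM in this assay, at which 1 of the 2 values shown sits), which places compound 1 at the weak end of what has been measured. A second compound, compound 2 `CCCCCc1ccc(-c2cn(C[C@H](O)[C@H]3OC(=O)C(OCc4ccccc4)=C3OCc3ccccc3)nn2)cc1`, is built on a different arrangement, and in this assay compound 2 gives 6220 nM. Within the data shown here, no step between two measured compounds that differ in a single place is available here. Compound 3 `COc1ccccc1-c1cn(C/C=C2\OC(=O)C(OCc3ccccc3)=C2OCc2ccccc2)nn1` has not yet been measured; it differs from compound 1 by 2-methoxyphenyl in place of 3,5-difluorophenyl on an aromatic carbon. With nothing shown about this exchange, the expected step of an at least 1.6-fold lower number from compound 1 to compound 3 (0.22 log units; that floor lies within the scatter) is a modest move toward stronger inhibition, though it may also be none beyond the scatter. Compound 3 is therefore expected to give about 60000 nM, with a range from 10000 nM to 300000 nM.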

Compound 3, half-maximal inhibitory concentration: > 100000 nM
Compound 3: no number, only a limit; the forecaster's own chance of this, stated with the estimate: 50%; at least 1.6-fold (0.22 log units) between middle value and limit.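

Compound 1 and compound 3 each give only a limit, not a number, in this assay, so no step between them can be read: the limit of > 100000 nM in this assay, at which 2 of the 3 values shown sit.

The compounds shown leave open whether 2-methoxyphenyl in place of 3,5-difluorophenyl changes antiproliferative activity at all.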